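A few compounds are considered here, and "the series" means these few. Any claim that something is new, unique, unknown or untested is made for them only; others in the source may bear on it.

Three compounds share one core and have been run in a physicochemical assay for lipophilicity, read by HPLC, in phosphate buffer, measured as chromatographic lipophilicity, at pH 7.4; on this read-out higher numbers stand for higher lipophilicity and lower numbers for lower lipophilicity. Compound 1 `COc1ccc2nc(C)cc(OCC(=O)Nc3cc(C)cc(C)c3)c2c1` gives 5.64. Compound 2 `Cc1cc(C)cc(NC(=O)COc2cc(C)nc3ccccc23)c1` gives 5.39. Compound 3 `Cc1cc(C)cc(NC(=O)COc2cc(C)nc3ccc(Cl)cc23)c1` gives 6.38, the highest of the three, standing above compound 1 by a number 0.74 log units higher from compound 1 to compound 3 (beyond the scatter) and above compound 2 by a number 0.99 log units higher from compound 2 to compound 3 (beyond the scatter). Compound 4 `Cc1cc(C)cc(NC(=O)COc2cc(C)nc3ccc(C)cc23)c1` differs from compound 3 by methyl in place of chloro on an aromatic carbon. Among the compounds with values here, no measured step swaps chloro for methyl, so the guide is only that chloro in place of hydrogen at this carbon gave a number 0.99 log units higher from compound 2 to compound 3 (beyond the scatter). Methyl is expected to keep most of that rise, so compound 4 is estimated at 6.15, between 5.75 and 6.55. The expected step from compound 3 to compound 4 is therefore a number 0.23 log units lower from compound 3 to compound 4 (within the scatter), within the scatter.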

Compound 4, distribution coefficient: 5.95
Beside the measured number, compound 4's estimate is 0.20 log units above it; low and high end bracket the measured number.
By their numbers in this assay, from the lowest: compounds 2 and 1 (each within the scatter of the next); then compound 4; then compound 3.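

In this assay, this aromatic carbon now has a second small group that raises the number over hydrogen (with methyl in place of hydrogen, a number 0.56 log units higher from compound 2 to compound 4 (beyond the scatter)), yet that rise is smaller than the one seen with chloro. Swapping chloro for methyl gives a real drop (a number 0.43 log units lower from compound 3 to compound 4 (beyond the scatter)), so these two groups of one heavy atom each are not interchangeable here. Methyl also separates from methoxy (a number 0.31 log units higher from compound 1 to compound 4 (beyond the scatter)), which hydrogen did not do. Nothing available explains why these groups differ. Still open, going by these compounds, is where an amine or a carboxylic acid at this carbon would fall relative to these four compounds.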